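Shifting Fluorines on a Cytotoxicity Series

The source may hold more compounds than are shown below. What is called first, only, known or untested is meant among the compounds shown, and "the series" means these compounds.

Compound 2 `CCOC(=O)c1cc(-c2cccc(OCc3cc(F)cc(F)c3)c2)on1` was tested in an ADME assay on Vero cells (Chlorocebus sabaeus) for cytotoxicity, with a stated time of 72 h; a higher number here means a weaker inhibitor, a lower number a stronger inhibitor. In this assay compound 2 gives > 128000 nM, which is a limit of the assay rather than a number. Compound 1 `CCOC(=O)c1cc(-c2cccc(OCc3cccc([N+](=O)[O-])c3)c2)on1` likewise gives > 128000 nM in this assay, also a limit. The step that the two limits leave unreadable from compound 1 to compound 2 cannot be read in size since (the limit of > 128000 nM in this assay, at which 2 of the 2 values shown sit). Compound 3 `CCOC(=O)c1cc(-c2cccc(OCc3cc(F)ccc3F)c2)on1` differs from compound 2 by 2,5-difluorophenyl in place of 3,5-difluorophenyl on a saturated chain carbon bound to an oxygen on an aromatic ring. Going by the values given here, no measured step readably bears on this change, so compound 3 is expected to remain at the limit, with an expected step that the limit leaves unreadable from compound 2 to compound 3 and no direction beyond the scatter. The estimate for compound 3 is 200000 nM, ranging from 100000 nM to 500000 nM.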

Compound 3, half-maximal inhibitory concentration: > 128000 nM
Compound 3: a limit, no number; the forecaster's own chance of this, stated with the estimate: 85%; the middle value lies beyond the limit too.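

The steps from compound 1 and from compound 2 to compound 3 cannot be read in size, since all three compounds stand at a limit: the limit of > 128000 nM in this assay, at which 3 of the 3 values shown sit. As far as these compounds go, whether 2,5-difluorophenyl, 3,5-difluorophenyl and 3-nitrophenyl differ at all in this assay stays open.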